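The compounds below may be only part of what the source reports. "The series", "measured", "known", "first", "only" and "open" are said of these compounds alone.

Measured compounds in an assay on isolated protein for inhibition of Amine oxidase [flavin-containing] B (Homo sapiens), read by fluorescence; a higher number here means a weaker inhibitor, a lower number a stronger inhibitor:

- compound 1 `N#Cc1ccc(OC/C=C/c2ccccc2)cc1C#N`: 642 nM
- compound 2 `N#Cc1cc2[nH]c(-c3ccccc3)c(Cl)c2cc1C#N`: 144 nM
- compound 3 `COc1ccc(-c2[nH]c3cc(C#N)c(C#N)cc3c2Cl)cc1`: 20 nM

Compound 2 sits second highest of the three numbers in this assay, closer to compound 1, which gives a higher number, than to compound 3, which gives a lower one. Within the data shown here, the single one-place step in the set runs from compound 2 to compound 3: a 7.2-fold lower number from compound 2 to compound 3 (0.86 log units; beyond the scatter), a methoxy in place of hydrogen on an aromatic carbon.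

Compound 4 `Cn1c(-c2ccccc2)c(Cl)c2cc(C#N)c(C#N)cc21` differs from compound 2 by methyl in place of hydrogen on an aromatic nitrogen. Among the measured compounds shown here, no measured step touches that aromatic nitrogen; the step from compound 2 to compound 3 concerns a carbon substituent and gives no guide to the size or direction here. With nothing to anchor it, the working expectation for compound 4 is a number near that of compound 2, with a wide range either way, and the estimated step of a 1.7-fold higher number from compound 2 to compound 4 (0.24 log units; within the scatter) is expected to be small. The estimate for compound 4 in this assay is 250 nM, expected to fall between 80 nM and 900 nM.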

Compound 4, half-maximal inhibitory concentration: > 100000 nM
Compound 4: no number, only a limit (the forecaster's own chance of this, stated with the estimate: 3%); middle value at least 400-fold (2.60 log units) away from the limit.
By their numbers in this assay, from the lowest: compound 3; then compound 2; then compound 1. At a limit, above all of these: compound 4.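

In this assay, methyl in place of hydrogen on the aromatic nitrogen gives an at least 690-fold higher number from compound 2 to compound 4 (2.84 log units; beyond the scatter), so adding a single carbon at this position has a large effect on the number. This is the only step shown at that nitrogen, and it runs the opposite way to the methoxy step on an aromatic carbon, a 7.2-fold lower number from compound 2 to compound 3 (0.86 log units; beyond the scatter). The value of compound 4 is a limit and not a number, so the size of its step is a lower bound only: the limit of > 100000 nM in this assay, at which 1 of the 4 values shown sits.

The compounds shown do not separate the presence of the methyl from the absence of the nitrogen hydrogen, and an ethyl or a longer chain on that nitrogen remains open. Also open, as far as these compounds go, is whether the methoxy of compound 3 would alter the outcome when methyl sits on the nitrogen.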